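From methyl to phenyl on compound 1

This account rests on a few compounds, and the source may have more. Where it says the series, first, only, none or still open, it means among the compounds named here.

Measured compounds:
- compound 1 `C=CC(=O)N1C(=O)CC(c2ccc(C)cc2)Sc2ccccc21`: 87600 nM
- compound 2 `C=CC(=O)N1C(=O)CCSc2ccccc21`: 565000 nM

Among the measured compounds shown here, in a functional assay on MOLT-4 cells (Homo sapiens) for cytotoxicity, read by CCK-8 assay, with a stated time of 24 h (on this read-out higher numbers stand for weaker inhibition and lower numbers for stronger inhibition), compound 1 gives 87600 nM, the lower of the two numbers so far. Compound 3 `C=CC(=O)N1C(=O)CC(c2ccc(-c3ccccc3)cc2)Sc2ccccc21` has not yet been measured. It differs from compound 1 by a single change: phenyl in place of methyl on an aromatic carbon, which is phenyl in place of methyl on an aromatic carbon, para to a large group. For the measured compounds named here, only one measured step bears on this, a 6.4-fold higher number from compound 1 to compound 2 (0.81 log units; beyond the scatter), and it is modest. That step replaces the whole 4-methylphenyl group with hydrogen, so it tests the change at the methyl only indirectly. A smaller step towards a lower number is therefore expected, and it may not clear the scatter. The estimate is an expected 1.5-fold lower number from compound 1 to compound 3 (0.16 log units; within the scatter). For compound 3 the expected value is 60000 nM, with an estimated range from 22000 nM to 170000 nM.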

Compound 3, half-maximal inhibitory concentration: 97500 nM
Beside the measured number, compound 3's estimate is 1.6-fold (0.21 log units) below it; the measured number falls inside the stated range.
By their numbers in this assay, from the lowest: compounds 1 and 3 (each within the scatter of the next); then compound 2.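

In this assay the earlier step, a 6.4-fold higher number from compound 1 to compound 2 (0.81 log units; beyond the scatter), removed the whole 4-methylphenyl group and so could not separate the ring from the group on it. The new step isolates that group: a 1.1-fold higher number from compound 1 to compound 3 (0.05 log units; within the scatter), so on this aromatic carbon, para to a large group, phenyl in place of methyl leaves the number within the scatter, even though phenyl brings one six-membered aromatic ring and more heavy atoms than methyl. Nothing available here accounts for this result.

Methyl and phenyl are the only groups shown on this aromatic carbon, and both are made of carbon alone. On these data alone, whether an amine, a carboxylic acid or a longer chain on the same carbon would also stay within the scatter of compound 1 remains open.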